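A Methyl Group Enters the Shared Core

The source may report more compounds than this note shows. Statements on the series, on what has been measured and on what is new or still open speak of the compounds shown alone.

compound 1, `O=c1oc(Nc2ccccc2I)nc2ccccc12`, 14700 nM
compound 2, `O=c1oc(Nc2ccccc2I)nc2ccc(Cl)cc12`, > 62500 nM

Compound 1 stands alone as the only number shown in an assay on isolated protein for inhibition of complement C1r subcomponent (Homo sapiens), with a stated time of 60 min (on this read-out higher numbers stand for weaker inhibition and lower numbers for stronger inhibition), where compound 1 gives 14700 nM. Compound 2 reaches only (the limit of > 62500 nM in this assay, at which 1 of the 2 values shown sits), a limit and not a number. Among the compounds with values here, the one measured step on this core, an at least 4.2-fold higher number from compound 1 to compound 2 (0.62 log units; beyond the scatter), shows that chloro in place of hydrogen on an aromatic carbon of the shared core pushed the read-out out of range.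

Compound 3, `Cc1ccc2c(=O)oc(Nc3ccccc3I)nc2c1`, is not yet measured. It differs from compound 1 by methyl in place of hydrogen on an aromatic carbon. The step from compound 1 to compound 2 is the only one that bears on it: a small substituent entering the same fused ring, though at a different place, gave a step that was at least modest and unfavourable. A methyl is a different group from a chloro, so the same outcome is not assured, but a change in the same direction is the more likely expectation.

The expected step is a 1.7-fold higher number from compound 1 to compound 3 (0.23 log units; within the scatter), weaker than compound 1. Compound 3 is therefore estimated at 25000 nM in this assay, within a range from 8000 nM to 80000 nM.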

Compound 3, half-maximal inhibitory concentration: 1500 nM
Compound 3: the middle estimate sits 17-fold (1.22 log units) above what was measured; measured number below the stated range.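

In this assay, methyl in place of hydrogen gave a 9.8-fold lower number from compound 1 to compound 3 (0.99 log units; beyond the scatter), the first step shown on the shared core that runs towards stronger inhibition; it shows that a single added carbon on this aromatic carbon, meta to a fused ring and para to a fused ring, can be more than tolerated. Compound 2, which carries chloro at a different place on the same core, points the other way, and its value is a limit and not a number: the limit of > 62500 nM in this assay, at which 1 of the 3 values shown sits. Nothing shown explains why the methyl on compound 3 had this effect.

The compounds shown leave open whether the gain belongs to methyl alone or extends to other groups at this place, such as ethyl, methoxy or an amine. They also leave open how methyl would read at the place chloro holds in compound 2 and how chloro would read at the place methyl holds in compound 3, so the effect of the group cannot yet be separated from the effect of its place.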